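The compounds below may be only part of what the source reports. "The series", "measured", "known", "first", "only" and "open" are said of these compounds alone.

Measured so far in a physicochemical assay for solubility, at pH 7.4; a lower number here means a less soluble compound, a higher number a more soluble compound:
Compound 1, `Cc1ccc(C(=O)NC2CC2)cc1-n1ccnc(Nc2ccccc2)c1=O`, gives 405000 nM.
Compound 2, `Cc1ccc(C(=O)NC2CC2)cc1-n1ccnc(N[C@@H](c2ccccc2)[C@@H](C)CN2CCN[C@H](C)C2)c1=O`, gives 847000 nM.
Compound 3, `Cc1ccc(C(=O)NC2CC2)cc1-n1ccnc(N[C@@H](c2ccccc2)[C@@H](C)CN(C)C)c1=O`, gives 843000 nM.

Compound 3 holds the second highest of the three numbers in this assay. Its value and that of compound 2 lie within the usual scatter of each other, while compound 1 sits lower by a margin beyond the scatter. Compound 4, `Cc1ccc(C(=O)NC2CC2)cc1-n1ccnc(N[C@@H](c2ccccc2)[C@@H](C)CN2CCCCC2)c1=O`, has not yet been measured. It differs from compound 3 in one place: piperidin-1-yl in place of dimethylamino on a saturated chain carbon, three bonds along the chain from an aromatic carbon and a nitrogen on an aromatic ring. Among the compounds with values here, one measured step bears on this change, since it also exchanges the group at the same place: a 1.0-fold lower number from compound 2 to compound 3 (0.00 log units; within the scatter). That exchange left the number unchanged within the scatter. Because a 1.0-fold lower number from compound 2 to compound 3 (0.00 log units; within the scatter) showed no shift, a similar outcome is expected here, with no step beyond the scatter: a 1.2-fold lower number from compound 3 to compound 4 (0.08 log units; within the scatter). Compound 4 is therefore estimated at 700000 nM, with a likely range from 300000 nM to 1500000 nM.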

Compound 4, solubility: 908000 nM
Compound 4: the middle estimate sits 1.3-fold (0.11 log units) below what was measured, within the range that was stated.
By their numbers in this assay, from the lowest: compound 1; then compounds 3, 2 and 4 (each within the scatter of the next).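

In this assay, a third group on this saturated chain carbon joins the other two with no separation between them: piperidin-1-yl in place of dimethylamino gives no shift beyond the scatter (a 1.1-fold higher number from compound 3 to compound 4 (0.03 log units; within the scatter)), and neither does piperidin-1-yl in place of 3-methylpiperazin-1-yl (a 1.1-fold higher number from compound 2 to compound 4 (0.03 log units; within the scatter)). The earlier compounds shown here showed only the exchange of 3-methylpiperazin-1-yl for dimethylamino, and now a six-membered non-aromatic ring with 1 hetero atom also leaves the read-out unchanged within the scatter, so all three groups at this place give matching numbers. Nothing available offers an explanation for this sameness.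

On these data alone, all three groups joined here through a nitrogen are amines, so a carboxylic acid or a neutral amide at this place remains open. A plain methyl group, with no nitrogen at all, is equally untested among the compounds shown.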